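Chloro in place of hydrogen on compound 2

This account rests on a few compounds, and the source may have more. Where it says the series, first, only, none or still open, it means among the compounds named here.

Measured in a functional assay on OVCAR-3 cells (Homo sapiens) for inhibition, read by sulforhodamine B assay, with a stated time of 48 h; on this read-out lower numbers stand for stronger inhibition of growth and higher numbers for weaker inhibition of growth:
- compound 1 `N#Cc1c(-c2nnc(O)c3nn(-c4ccc(Cl)cc4)cc23)nn(-c2ccccc2)c1-c1ccccc1`: 33400 nM
- compound 2 `N#Cc1c(-c2nnc(-c3nn(-c4ccccc4)c(-c4ccccc4)c3C#N)c3nn(-c4ccccc4)cc23)nn(-c2ccccc2)c1-c1ccccc1`: 7260 nM

Compound 2 has the lower number of the two at 7260 nM, a gap beyond the scatter from compound 1. For the measured compounds named here, these two compounds differ in more than one place, so no single-change step is available. Compound 3 `N#Cc1c(-c2nnc(-c3nn(-c4ccccc4)c(-c4ccccc4)c3C#N)c3nn(-c4ccc(Cl)cc4)cc23)nn(-c2ccccc2)c1-c1ccccc1` arises from compound 2 by chloro in place of hydrogen on an aromatic carbon, phenyl to 4-chlorophenyl. Compound 1 also carries 4-chlorophenyl, but its other differences leave this change unresolved. The expected change in this assay is a 1.2-fold lower number from compound 2 to compound 3 (0.08 log units; within the scatter), which stays within the scatter. The estimate for compound 3 is 6000 nM, with an expected range of 2500 nM to 15000 nM.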

Compound 3, concentration for 50% growth inhibition: 95800 nM
Compound 3: the middle estimate sits 16-fold (1.20 log units) below what was measured; measured number above the stated range.
By their numbers in this assay, from the lowest: compound 2; then compound 1; then compound 3.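

In this assay, phenyl to 4-chlorophenyl gives a 13-fold higher number from compound 2 to compound 3 (1.12 log units; beyond the scatter) and weakens growth inhibition, so this position is sensitive to a single added chlorine atom. For the compounds shown here, compound 1 also carries 4-chlorophenyl but differs from compound 2 in more than one place, so only this step isolates the change. Nothing measured on these compounds accounts for the loss. From the compounds shown here alone, whether the loss is specific to chloro remains open, and fluoro or methoxy on the same carbon would test that. Going by these compounds, whether chloro on the other phenyl rings behaves likewise is also open.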